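Swapping Hydroxyamino for Aminoamino: An Expected Value

The compounds below may be only part of what the source reports. "The series", "measured", "known", "first", "only" and "open" are said of these compounds alone.

Measured so far in a functional assay on HepG2 cells (Homo sapiens) for antiproliferative activity, read by MTT assay, with a stated time of 48 h; on this read-out higher numbers stand for weaker inhibition and lower numbers for stronger inhibition:
compound 1 `Cc1ccc(C(=O)Nc2ccc(Cl)cc2C(N)=O)cc1` gives 21 ug/mL
compound 2 `Cc1ccc(-c2nc(N)c3cc(Cl)ccc3n2)cc1` gives 14.5 ug/mL
compound 3 `Cc1ccc(-c2nc(NO)c3cc(Cl)ccc3n2)cc1` gives 23.1 ug/mL

Compound 3 shows the highest of the three numbers in this assay, but compound 1 lies closest to it and compound 2 is within the usual scatter as well, so none of the three can be set apart from the others on this read-out. Among the measured compounds shown here, the one change already made at the same position on the shared core of compound 2 and compound 3, a 1.6-fold higher number from compound 2 to compound 3 (0.20 log units; within the scatter), stayed within the scatter: a hydroxy on that ring nitrogen in place of hydrogen shifted the number only slightly.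

Compound 4 `Cc1ccc(-c2nc(NN)c3cc(Cl)ccc3n2)cc1` has not yet been measured in this assay. It differs from compound 3 by amino in place of hydroxy on a nitrogen on an aromatic ring. For the measured compounds named here, only that single step bears on this position, and it was small, so a step of similar size in this assay, in either direction or none beyond the scatter, is expected here. The estimated step is a 1.3-fold lower number from compound 3 to compound 4 (0.11 log units; within the scatter). Compound 4 is therefore expected to give about 18 ug/mL in this assay, with a range from 9 ug/mL to 40 ug/mL.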

Compound 4, half-maximal inhibitory concentration: 4.17 ug/mL
Compound 4: the middle estimate sits 4.3-fold (0.64 log units) above what was measured, and the stated range ends above it.
By their numbers in this assay, from the lowest: compound 4; then compounds 2, 1 and 3 (each within the scatter of the next).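

In this assay, this position on the nitrogen on an aromatic ring now responds beyond the scatter, with a 5.5-fold lower number from compound 3 to compound 4 (0.74 log units; beyond the scatter) on amino in place of hydroxy and a 3.5-fold lower number from compound 2 to compound 4 (0.54 log units; beyond the scatter) on amino in place of hydrogen. The earlier hydroxy step alone gave no such sign, so among the three groups shown here, only amino sets its compound apart. Hydroxy and amino match in their heavy-atom, hydrogen-bond donor, hydrogen-bond acceptor and charge counts, so those counts do not separate them, and nothing available explains the difference.

From the compounds shown here alone, it remains open whether the lower number is particular to amino or would persist with a methylamino group or a longer chain on that nitrogen. Going by these compounds, it is also open whether the step would hold if the chloro or methyl group on the shared core were replaced.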